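Replacing 3-hydroxyphenyl with 2-chlorophenyl on the shared core

The compounds below may be only part of what the source reports. "The series", "measured", "known", "first", "only" and "open" are said of these compounds alone.

In an ADME assay on HEL cells (Homo sapiens) for cytotoxicity (a lower number here means that less compound is tolerated, a higher number that more compound is tolerated), compound 1 `O=C(COc1cccc2ccccc12)N/N=C/c1cccc(O)c1` gives 62.7 ug/mL and sits level with compound 3 `O=C(COc1cccc2ccccc12)N/N=C/c1cccc([N+](=O)[O-])c1` at 61.2 ug/mL within the scatter, while compound 2 `COc1ccc(/C=N/NC(=O)COc2cccc3ccccc23)cc1O` stands lower at 27.7 ug/mL in the same measurement. Compound 4 `O=C(COc1cccc2ccccc12)N/N=C/c1ccccc1Cl` has not been measured yet. It differs from compound 1 on a carbon with a double bond to nitrogen (2-chlorophenyl in place of 3-hydroxyphenyl on a carbon with a double bond to nitrogen), with 2-chlorophenyl in place of 3-hydroxyphenyl.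

Among the compounds with values here, two measured steps bear on this change. Nitro in place of hydroxy on an aromatic carbon gave a 1.0-fold lower number from compound 1 to compound 3 (0.01 log units; within the scatter) and so stayed within the scatter, which suggests that compound 1 tolerates losing its hydroxy. Methoxy in place of hydrogen on an aromatic carbon gave a 2.3-fold lower number from compound 1 to compound 2 (0.35 log units; beyond the scatter) as a modest step. Within the data shown here, no measured compound carries chlorine, so the evidence is indirect. Only a small downward step is expected, and the estimated step is a 1.3-fold lower number from compound 1 to compound 4 (0.10 log units; within the scatter) in this assay without clearing the scatter. The estimated value for compound 4 is 50 ug/mL with an expected range between 25 ug/mL and 90 ug/mL for the measurement.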

Compound 4, half-maximal cytotoxic concentration: 62.7 ug/mL
Estimate against measurement, compound 4: 1.3-fold (0.10 log units) below; low and high end bracket the measured number.
By their numbers in this assay, from the lowest: compound 2; then compounds 3, 1 and 4 (each within the scatter of the next).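

In this assay, replacing 3-hydroxyphenyl with 2-chlorophenyl on a carbon with a double bond to nitrogen gave no change at the digits printed from compound 1 to compound 4 (within the scatter), so this position accepts a change of the whole aryl group, not only the exchange of one substituent seen with compound 3. Within the data shown here, compound 4 also brings in chlorine, which no earlier compound carried, and its entering group has 0 hydrogen-bond donors and 0 hydrogen-bond acceptors, yet the number stays within the scatter of compound 1. No measurement shown gives a reason for this result.

The compounds shown leave open whether a phenyl group carrying a carboxylic acid or an amine would be tolerated as well. They also leave open whether chlorine elsewhere on the phenyl group would give the same number.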